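A few compounds are considered here, and "the series" means these few. Any claim that something is new, unique, unknown or untested is made for them only; others in the source may bear on it.

For the measured compounds named here, compound 3 `O=C(CN(c1nc(Cl)nc2[nH]cnc12)C1CC1)NCC(=O)OCc1ccccc1` gives, in a functional assay on the whole organism (Tail, strain ICR) with Mus musculus as the target, in the tail flick test, with a stated time of 120 min, at a dose of 25 umol/kg by the oral route (on this read-out higher numbers stand for a stronger effect at the one dose given and lower numbers for a weaker effect), 21.7%, the lowest of the three numbers known here. Compound 1 `O=C(CN(c1nc(Cl)nc2[nH]cnc12)C1CC1)N[C@@H](CO)C(=O)OCc1ccccc1` gives 34.5% and compound 2 `C[C@H](NC(=O)CN(c1nc(Cl)nc2[nH]cnc12)C1CC1)C(=O)OCc1ccccc1` gives 36.1%; a number 1.6 percentage points higher from compound 1 to compound 2 (within the scatter). Compound 4 `CC(C)[C@H](NC(=O)CN(c1nc(Cl)nc2[nH]cnc12)C1CC1)C(=O)OCc1ccccc1` differs from compound 3 by isopropyl in place of hydrogen on a saturated chain carbon bound to an amide-type nitrogen and a carbonyl carbon. Going by the values given here, two measured steps bear on this place: a number 14.4 percentage points lower from compound 2 to compound 3 (beyond the scatter), and a number 12.8 percentage points lower from compound 1 to compound 3 (beyond the scatter). In both cases removing a group from that carbon lowered the number by a modest amount. A step of similar size in the other direction is therefore expected for compound 4, with the entering isopropyl: a number 13.3 percentage points higher from compound 3 to compound 4 (beyond the scatter). Compound 4 is expected to give about 35%, within a range from 22% to 48%.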

Compound 4, a percentage reported as activity, at one dose (the size of the read-out at that dose, not a potency): 27.3%
Beside the measured number, compound 4's estimate is 7.7 percentage points above it, within the range that was stated.
By their numbers in this assay, from the lowest: compounds 3, 4, 1 and 2 (each within the scatter of the next, the first and the last beyond it).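

Unlike methyl and hydroxymethyl, isopropyl on this saturated chain carbon gives a step from hydrogen that stays within the scatter (a number 5.6 percentage points higher from compound 3 to compound 4 (within the scatter)). Isopropyl also stays within the scatter of both those groups (a number 8.8 percentage points lower from compound 2 to compound 4 (within the scatter); a number 7.2 percentage points lower from compound 1 to compound 4 (within the scatter)), so compound 4 cannot be ranked against any of the other three compounds. Nothing available explains this result. In this assay, on these data alone, the outcome with a benzyl group, a longer chain or an amine on this carbon stays open.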